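Ethoxy for ethyl on a scaffold tolerated by cells

The source may hold more compounds than are shown below. What is called first, only, known or untested is meant among the compounds shown, and "the series" means these compounds.

Measured so far:
compound 1 `CCCCNc1nc(N)nc2ccn(Cc3ccccc3)c12` — > 24000 nM
compound 2 `CCCCNc1nc(N)nc2ccn(Cc3ccccn3)c12` — > 24000 nM

In an ADME assay on HEK293 cells (Homo sapiens) for cytotoxicity, read by ATP content, with a stated time of 6 h (a higher number here means that more compound is tolerated, a lower number that less compound is tolerated), compound 1 `CCCCNc1nc(N)nc2ccn(Cc3ccccc3)c12` reaches only a limit of the assay, > 24000 nM. Compound 2 `CCCCNc1nc(N)nc2ccn(Cc3ccccn3)c12` likewise reaches only a limit, > 24000 nM. The step that the two limits leave unreadable from compound 1 to compound 2 is therefore unreadable from the two limits. Where compound 2 stands is thus known only as a limit, and it shares that position with compound 1: the limit of > 24000 nM in this assay, at which 2 of the 2 values shown sit.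

Compound 3 `CCOCCNc1nc(N)nc2ccn(Cc3ccccn3)c12` is the next compound, not yet measured in this assay. Its difference from compound 2 is ethoxy in place of ethyl on a saturated chain carbon, two bonds along the chain from a nitrogen on an aromatic ring. Among the measured compounds shown here, the only measured step, a step that the two limits leave unreadable from compound 1 to compound 2, concerns a different part of the molecule and gives no readable size, so no measured step bears on this change in this assay. The account expects that compound 3 stays where compound 2 stands, with an expected step that the limit leaves unreadable from compound 2 to compound 3 that is none beyond the scatter. The estimate for compound 3 in this assay is therefore 30000 nM, ranging from 15000 nM to 80000 nM, most likely again reported as a limit.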

Compound 3, half-maximal cytotoxic concentration: > 24000 nM
Compound 3: a limit, no number (the forecaster's own chance of this, stated with the estimate: 80%); the middle value is on the limit's open side.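

In this assay compound 3 gives > 24000 nM, a limit of the assay and not a number. No step can therefore be read between compound 2 and compound 3, which stand together with compound 1: the limit of > 24000 nM in this assay, at which 3 of the 3 values shown sit.

The compounds shown leave open whether ethoxy in place of ethyl alters how much compound the cells tolerate.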